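Moving the Acid Group on a Bile Acid Receptor Agonist

This account rests on a few compounds, and the source may have more. Where it says the series, first, only, none or still open, it means among the compounds named here.

compound 1 `CN(Cc1ccc(C(=O)O)cc1)c1ccc(OCc2c(-c3c(Cl)cccc3Cl)noc2C2CC2)nc1C(F)(F)F`: 12 nM
compound 2 `O=C(O)c1cccc(OCc2ccc(OCc3c(-c4c(Cl)cccc4Cl)noc3C3CC3)nc2C(F)(F)F)c1`: 43 nM

In an assay on isolated protein for agonist activity at Bile acid receptor (Homo sapiens), read by FRET (a higher number here means that more compound is needed for the effect, a lower number that less compound is needed), compound 2 gives the higher of the two numbers; the step of a 3.6-fold higher number from compound 1 to compound 2 (0.55 log units; beyond the scatter) separates it from compound 1. Compound 3 `O=C(O)c1ccc(OCc2ccc(OCc3c(-c4c(Cl)cccc4Cl)noc3C3CC3)nc2C(F)(F)F)cc1` differs from compound 2 by 4-carboxyphenyl in place of 3-carboxyphenyl on an oxygen on a saturated carbon. Within the data shown here, no measured step isolates this change; the only step available, a 3.6-fold higher number from compound 1 to compound 2 (0.55 log units; beyond the scatter), alters the linker and the acid's position together, so it bears on compound 3 only loosely. Compound 1, which carries its acid as (4-carboxybenzyl)(methyl)amino, gives 12 nM. Compound 3 is therefore expected near 30 nM, within 10 nM to 100 nM. This estimate corresponds to an expected step of a 1.4-fold lower number from compound 2 to compound 3 (0.16 log units; within the scatter).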

Compound 3, half-maximal effective concentration: 76 nM
Compound 3: the middle estimate sits 2.5-fold (0.40 log units) below what was measured; measured number inside the range.
By their numbers in this assay, from the lowest: compound 1; then compounds 2 and 3 (each within the scatter of the next).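

In this assay, 4-carboxyphenyl in place of 3-carboxyphenyl on the oxygen gives a 1.8-fold higher number from compound 2 to compound 3 (0.25 log units; within the scatter) and so does not separate these two placements of the acid. With the 4-carboxy arrangement kept, (4-carboxyphenoxy)methyl in place of (4-carboxybenzyl)(methyl)amino gives a 6.3-fold higher number from compound 1 to compound 3 (0.80 log units; beyond the scatter) and so the gap to compound 1 now appears without any shift of the acid, with the linker exchange alone. Nothing available here accounts for either step.

As far as these compounds go, whether 3-carboxyphenyl would read the same on the methylamino linker of compound 1 stays open. So does whether a tetrazole or a primary amide could stand in for the carboxylic acid on either linker.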